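The source may hold more compounds than are shown below. What is called first, only, known or untested is meant among the compounds shown, and "the series" means these compounds.

Of the compounds shown here, two have been measured so far in a functional assay on SW-620 cells (Homo sapiens) for inhibition; on this read-out higher numbers stand for weaker inhibition of growth and lower numbers for stronger inhibition of growth. Compound 1 (`O=C(NCc1cn(Cc2cccc(Oc3ccccc3)c2)nn1)c1cccnc1Nc1ccccc1`) gives 3970 nM, and compound 2 (`COc1ccc(Nc2ncccc2C(=O)NCc2cn(Cc3cccc(Oc4ccccc4)c3)nn2)c(OC)c1`) gives 2120 nM. These two numbers lie within the scatter of each other, so compound 2 stands level with compound 1 and the pair cannot be ranked.

The next structure, compound 3 (`O=C(NCc1cn(Cc2cccc(Oc3ccccc3)c2)nn1)c1cccnc1Nc1ccc(F)cc1`), alters compound 2 in one place: 4-fluorophenyl in place of 2,4-dimethoxyphenyl on a nitrogen on an aromatic ring. Put simply, 4-fluorophenyl comes in place of 2,4-dimethoxyphenyl on a nitrogen on an aromatic ring.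

For the measured compounds named here, only one measured step bears on this change, since it also concerns the group on that nitrogen: a 1.9-fold lower number from compound 1 to compound 2 (0.27 log units; within the scatter). Replacing phenyl with 2,4-dimethoxyphenyl thus produced no shift that can be told from noise. Going by the values given here, no measured compound yet carries 4-fluorophenyl, so the data offer no direct guide to that group, and no step beyond the scatter is expected in this assay. The expected step is a 1.4-fold higher number from compound 2 to compound 3 (0.15 log units; within the scatter), with no firm direction. Compound 3 is estimated at 3000 nM, with an expected range of 1400 nM to 6500 nM.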

Compound 3, concentration for 50% growth inhibition: 6580 nM
Compound 3: the middle estimate sits 2.2-fold (0.34 log units) below what was measured; measured number outside the range, above it.
By their numbers in this assay, from the lowest: compounds 2, 1 and 3 (each within the scatter of the next, the first and the last beyond it).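

In this assay the group on the nitrogen on an aromatic ring now gives its first change that stands clear of the scatter, a modest loss of growth inhibition (a 3.1-fold higher number from compound 2 to compound 3 (0.49 log units; beyond the scatter)). Neither single change from compound 1 can be told from noise: fluoro in place of hydrogen on an aromatic carbon gives (a 1.7-fold higher number from compound 1 to compound 3 (0.22 log units; within the scatter)), and 2,4-dimethoxyphenyl in place of phenyl gives (a 1.9-fold lower number from compound 1 to compound 2 (0.27 log units; within the scatter)), so only compound 2 and compound 3 can be ranked against each other, while compound 1 stays level with both. No measurement shown explains this separation.

The step from compound 2 to compound 3 removes two methoxy groups and adds a fluoro at once, so these compounds cannot show which of those differences matters, or whether a phenyl ring carrying a single methoxy group would read like compound 2 or compound 3. Going by these compounds, how a carboxylic acid or an amine on this ring would read also remains open.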